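The source may report more compounds than this note shows. Statements on the series, on what has been measured and on what is new or still open speak of the compounds shown alone.

Measured so far:
compound 1, `CCC(CO)NCc1nc2c(OCC3CCCCC3)cccc2[nH]1`, 94.3%
compound 2, `OCCC(NCc1nc2c(OCC3CCCCC3)cccc2[nH]1)c1ccccc1`, 64.7%
compound 3, `OCC(CC1CCCCC1)NCc1nc2c(OCC3CCCCC3)cccc2[nH]1`, 94.7%

All three share one core and differ only in the group on the amine nitrogen. In an assay on cells for inhibition of interleukin-5 receptor subunit alpha (Mus musculus), read by WST assay, with a stated time of 48 h, tested at 30 uM, in the presence of a further agent that is not named here (on this read-out lower numbers stand for less inhibition and higher numbers for more inhibition at the one concentration tested (going by the name of the read-out)), compound 1 gives 94.3%, the second highest of the three numbers; compound 3 gives 94.7%, and the gap between them, a number 0.4 percentage points higher from compound 1 to compound 3 (within the scatter), is within the scatter. Compound 2 gives 64.7%, clearly lower than compound 1.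

Compound 4, `c1ccc(NCc2nc3c(OCC4CCCCC4)cccc3[nH]2)cc1`, has not been measured. Compared with compound 1 the change is phenyl in place of 1-(hydroxymethyl)propyl on an amine nitrogen. Among the compounds with values here, the one measured step, a number 0.4 percentage points higher from compound 1 to compound 3 (within the scatter), swaps a group two bonds from the nitrogen and changed little, so it does not speak directly to replacing the whole chain with phenyl. Within the data shown here, compound 2, whose nitrogen substituent also carries a phenyl, shows a lower number than compound 1, but no step between them is given. A moderate drop is therefore expected in this assay: compound 4 is estimated at 70%, between 40% and 92%, a change of a number 24.3 percentage points lower from compound 1 to compound 4 (beyond the scatter).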

Compound 4, a percentage reported as inhibition, at one concentration (the size of the read-out at that concentration, not a potency): 25%
Compound 4: the middle estimate sits 45 percentage points above what was measured, and the stated range ends above it.
By their numbers in this assay, from the lowest: compound 4; then compound 2; then compounds 1 and 3 (each within the scatter of the next).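

The earlier step on the chain, a number 0.4 percentage points higher from compound 1 to compound 3 (within the scatter), left the number in this assay in place, but the group on this amine nitrogen cannot be swapped freely: phenyl in place of 1-(hydroxymethyl)propyl is a large step, a number 69.3 percentage points lower from compound 1 to compound 4 (beyond the scatter). This one change does several things at once, as the group that leaves has a hydrogen-bond donor and a hydrogen-bond acceptor, the group that enters has neither, and a six-membered aromatic ring now sits directly on the nitrogen. Nothing available bears on the cause of this drop.

On these data alone, it remains open whether the loss follows the missing hydroxyl or the arrival of the ring. A sec-butyl group, which keeps the chain without its hydroxyl, and a benzyl group on the nitrogen would help to tell these apart.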